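Swapping a Hydroxy for a Methyl: What to Expect

This account rests on a few compounds, and the source may have more. Where it says the series, first, only, none or still open, it means among the compounds named here.

Of the compounds shown here, two sharing one core have so far been tested in a functional assay on A2780 cells (Homo sapiens) for cytotoxicity, read by MTT assay, with a stated time of 68 h; on this read-out lower numbers stand for stronger inhibition and higher numbers for weaker inhibition. Compound 1 `O=C(/C=C/c1cccc(OCc2ccccc2)c1)c1ccc([N+](=O)[O-])cc1` gives 56400 nM. Compound 2 `O=C(/C=C/c1cccc(OCc2ccccc2)c1)c1ccc(O)cc1` gives 1000 nM. That makes compound 2 the lower of the two numbers, with a 56-fold lower number from compound 1 to compound 2 (1.75 log units; beyond the scatter) separating them; the change there was hydroxy in place of nitro on an aromatic carbon.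

Compound 3 `Cc1ccc(C(=O)/C=C/c2cccc(OCc3ccccc3)c2)cc1` has not yet been measured. It differs from compound 2 at the same aromatic carbon: methyl in place of hydroxy on an aromatic carbon.

Among the compounds with values here, only one measured step exists, and it concerns that carbon, but it exchanged nitro for hydroxy rather than hydroxy for methyl, so it bears on the new step only indirectly. It does show that the group at this carbon can move the number a great deal. Without a direct precedent, a moderate rise in the number is expected, well short of what the nitro compound showed.

Compound 3 is estimated at 5000 nM, within a range from 1000 nM to 25000 nM, which means an expected step of a 5.0-fold higher number from compound 2 to compound 3 (0.70 log units; beyond the scatter).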

Compound 3, half-maximal inhibitory concentration: 20500 nM
Beside the measured number, compound 3's estimate is 4.1-fold (0.61 log units) below it; the range from low to high includes it.
By their numbers in this assay, from the lowest: compound 2; then compound 3; then compound 1.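

The earlier step could be read as nitro simply being a poor group at this carbon, but this result shows that the low number depends on hydroxy. In this assay, replacing hydroxy with methyl, one heavy atom for one, brings a 21-fold higher number from compound 2 to compound 3 (1.31 log units; beyond the scatter). Methyl and nitro also lie much closer to each other than either lies to hydroxy, with a 2.8-fold lower number from compound 1 to compound 3 (0.44 log units; beyond the scatter), so among these three groups hydroxy is the one that stands apart, although methyl still keeps a modest edge over nitro. By the count, the swap to methyl removes one hydrogen-bond donor and one hydrogen-bond acceptor, but that is only a structural difference, and nothing measured here connects it to the shift in the number.

The compounds shown leave open how an amine, a methoxy group or a carboxylic acid at this carbon would compare with hydroxy, and such groups could help show which feature of hydroxy matters. They also leave open whether swapping 4-hydroxyphenyl for 4-methylphenyl would produce a step of similar size on any core other than this one.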